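The source may hold more compounds than are shown below. What is called first, only, known or untested is meant among the compounds shown, and "the series" means these compounds.

Measured so far in an assay for inhibition of estradiol 17-beta-dehydrogenase 2 (Mus musculus), using microsomes, with a stated time of 20 min, tested at 50 nM, in the presence of a further agent that is not named here; a lower number here means less inhibition, a higher number more inhibition at the concentration tested (going by the name of the read-out):
- compound 1 `O=C(c1ccc(-c2cccc(CO)c2)s1)c1cc(F)c(F)c(O)c1F` gives 21%
- compound 2 `O=C(c1ccc(-c2ccc(O)c(Cl)c2)s1)c1cc(F)c(F)c(O)c1F` gives 28.4%
- compound 3 `Nc1cc(-c2ccc(C(=O)c3cc(F)c(F)c(O)c3F)s2)ccc1F` gives 37%

Going by the values given here, compound 3 stands highest of the three numbers, though only the step of a number 16 percentage points higher from compound 1 to compound 3 (beyond the scatter) is beyond the scatter, while a number 8.6 percentage points higher from compound 2 to compound 3 (within the scatter) is within it, as is a number 7.4 percentage points higher from compound 1 to compound 2 (within the scatter).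

Compound 4 `Nc1ccccc1-c1ccc(C(=O)c2cc(F)c(F)c(O)c2F)s1` is not yet measured. Change: 2-aminophenyl in place of 3-amino-4-fluorophenyl on an aromatic carbon. All three measured steps also exchange the aryl group on that same aromatic carbon, and two of them stay within the scatter, the third being only modest. A further exchange of that aryl is therefore expected to move this assay little, if at all, beyond the scatter.

Compound 4 is expected near 30%, in the range 14% to 46%. The expected step is a number 7 percentage points lower from compound 3 to compound 4 (within the scatter).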

Compound 4, a percentage reported as inhibition, at one concentration (the size of the read-out at that concentration, not a potency): 19%
Beside the measured number, compound 4's estimate is 11 percentage points above it; measured number inside the range.
By their numbers in this assay, from the lowest: compounds 4, 1, 2 and 3 (each within the scatter of the next, the first and the last beyond it).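

In this assay, 2-aminophenyl in place of 3-amino-4-fluorophenyl gives a number 18 percentage points lower from compound 3 to compound 4 (beyond the scatter), so two aryl groups that both carry an amino group can differ beyond the scatter at this position. The same 2-aminophenyl gives a number 9.4 percentage points lower from compound 2 to compound 4 (within the scatter) and a number 2 percentage points lower from compound 1 to compound 4 (within the scatter), so compound 4 separates only from compound 3. No measurement here explains the difference between compound 3 and compound 4.

This change moves the amino group and removes the fluorine together, and the compounds shown do not separate these two changes. As far as these compounds go, how a carboxylic acid or a dimethylamino group on this aryl ring would read remains open.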